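Swapping a Thiophene for a Methylpyrimidine: Expected Cytotoxicity

The source may report more compounds than this note shows. Statements on the series, on what has been measured and on what is new or still open speak of the compounds shown alone.

Measured so far in a toxicity assay on MT4 cells (Homo sapiens) for cytotoxicity, read by MTT assay, with a stated time of 5 days; on this read-out lower numbers stand for higher toxicity in this test and higher numbers for lower toxicity in this test:
compound 1 `Cc1cnc(Nc2ccc(C#N)cc2)nc1Nc1c(F)cc(-c2ccoc2)cc1F` gives 4200 nM
compound 2 `Cc1cnc(Nc2ccc(C#N)cc2)nc1Nc1c(F)cc(-c2ccnc(F)c2)cc1F` gives 167000 nM
compound 3 `Cc1cc(-c2cccs2)cc(C)c1Nc1ccnc(Nc2ccc(C#N)cc2)n1` gives 10000 nM

Among these three, compound 3 stands second highest: compound 1 sits at a lower number, compound 2 at a clearly higher one. Compound 4 `Cc1ncc(-c2cc(C)c(Nc3ccnc(Nc4ccc(C#N)cc4)n3)c(C)c2)cn1` differs from compound 3 in a single place: 2-methylpyrimidin-5-yl in place of thiophen-2-yl on an aromatic carbon. Among the compounds with values here, the one comparable change seen so far is a 40-fold higher number from compound 1 to compound 2 (1.60 log units; beyond the scatter), where a six-membered aromatic ring likewise replaced a five-membered one on an aromatic carbon. A step of similar character is therefore expected here, toward a higher number and thus lower toxicity, estimated at a 10-fold higher number from compound 3 to compound 4 (1.00 log units; beyond the scatter). Compound 4 is expected to give 100000 nM, with a likely range from 20000 nM to 300000 nM.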

Compound 4, half-maximal cytotoxic concentration: 3900 nM
Compound 4: middle estimate off by 26-fold (1.41 log units), on the high side; the whole stated range lies above it.
By their numbers in this assay, from the lowest: compounds 4 and 1 (each within the scatter of the next); then compound 3; then compound 2.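

In this assay, the swap at this position gives a 2.6-fold lower number from compound 3 to compound 4 (0.41 log units; beyond the scatter), so a six-membered aromatic ring replacing a five-membered one points toward higher toxicity in this test, against the direction of a 40-fold higher number from compound 1 to compound 2 (1.60 log units; beyond the scatter). The direction of such a ring swap therefore does not carry over between these two pairs, whose cores and incoming rings differ. Nothing available explains this difference in direction. Still open, from the compounds shown here alone, is how a non-ring group here, such as an amine or a carboxylic acid, would compare with 2-methylpyrimidin-5-yl. Also open, going by these compounds, is how 2-methylpyrimidin-5-yl would behave on the core of compound 1.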